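Swapping a Side Chain for an Amine

The source may hold more compounds than are shown below. What is called first, only, known or untested is meant among the compounds shown, and "the series" means these compounds.

Three compounds share a core built around the structure of compound 1 `O=C(NC1(C(=O)NO)CCS(=O)(=O)CC1)c1ccc(C#Cc2ccccc2)cc1`, which in a physicochemical assay for solubility (a lower number here means a less soluble compound, a higher number a more soluble compound), gives 2000 nM. Compound 3 `O=C(NC1(C(=O)NO)CCOCC1)c1ccc(C#Cc2ccccc2)cc1` gives 5000 nM in this assay. Compound 2 `COCCNC(=O)C[C@H](NC(=O)c1ccc(C#Cc2ccccc2)cc1)C(=O)NO` reaches 78000 nM in this assay, the highest of the three numbers; its nearest neighbour is compound 3 and its most distant is compound 1, both gaps lying beyond the usual scatter.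

Compound 4 `NC[C@H](NC(=O)c1ccc(C#Cc2ccccc2)cc1)C(=O)NO` has not yet been measured in this assay. It differs from compound 2 by amino in place of (2-methoxyethyl)carbamoyl on a saturated chain carbon, two bonds along the chain from an amide-type nitrogen and a carbonyl carbon. The group that leaves is a chain of seven heavy atoms, while the group that enters is a single nitrogen, so compound 4 is a much smaller molecule than compound 2.

Among the compounds with values here, no measured pair here shows this exact change, so the size of the step is uncertain. The expectation is that compound 4 moves upward from compound 2 by a 2.6-fold higher number from compound 2 to compound 4 (0.41 log units; beyond the scatter), to an estimated 200000 nM in this assay, with a range from 60000 nM to 600000 nM.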

Compound 4, solubility: 13000 nM
Compound 4: middle estimate off by 15-fold (1.19 log units), on the high side; the whole stated range lies above it.
By their numbers in this assay, from the lowest: compound 1; then compound 3; then compound 4; then compound 2.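

In this assay, putting amino in place of (2-methoxyethyl)carbamoyl on a saturated chain carbon gives a 6.0-fold lower number from compound 2 to compound 4 (0.78 log units; beyond the scatter) and so shows that the number at this position depends on the group attached there. Within the data shown here, it also shows that the much smaller amino group does not raise the number, and this is the only step in the set that changes just one place, so it is the only direct reading of this position. Nothing in the available data explains why the number falls.

A single step cannot separate the loss of the (2-methoxyethyl)carbamoyl group from the arrival of the amino group. A shorter amide, a carboxylic acid or a longer chain ending in an amine at this place would help to tell these two apart.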